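Amide-side phenyl for cyclohexyl on the ethyl pyroglutamide

The source may report more compounds than this note shows. Statements on the series, on what has been measured and on what is new or still open speak of the compounds shown alone.

Measured so far:
compound 1 `O=C(NCc1ccc(F)cc1Cl)[C@@H]1CCC(=O)N1C1CCCC1`: 501 nM
compound 2 `CCN1C(=O)CC[C@H]1C(=O)NCC1CCCCC1`: < 1000 nM

In an assay on isolated protein for inhibition of P2X purinoceptor 7 (Homo sapiens) (a lower number here means a stronger inhibitor, a higher number a weaker inhibitor), compound 1 gives 501 nM. For compound 2 the read-out is only a limit, < 1000 nM, not a number. Within the data shown here, compound 2 therefore stands without a fixed place among the values shown, and no step between compound 1 and compound 2 can be sized. The two compounds also differ in more than one place, so nothing about a single change can be drawn from them.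

Compound 3 `CCN1C(=O)CC[C@H]1C(=O)NCc1ccccc1` differs from compound 2 by phenyl in place of cyclohexyl on a saturated chain carbon bound to an amide-type nitrogen, in words phenyl in place of cyclohexyl on a saturated chain carbon bound to an amide-type nitrogen. Among the measured compounds shown here, no measured pair shows this change, so its size is unknown here. Compound 1, which carries an aromatic ring on the same kind of carbon, reaches 501 nM, which suggests that an aromatic ring is tolerated in this position.

Compound 3 is expected to give about 700 nM, within 200 nM to 2500 nM. The implied step that the limit leaves unreadable from compound 2 to compound 3 is estimated to be small, at or near the scatter, in either direction.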

Compound 3, half-maximal inhibitory concentration: < 1000 nM
Compound 3 ended at the assay's limit; the forecaster's own chance of this, stated with the estimate: 35%; the middle value does not contradict the limit.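

In this assay no step from compound 2 to compound 3 can be read, because both stand at a limit and not at a number: the limit of < 1000 nM in this assay, at which 2 of the 3 values shown sit.

Still open, from the compounds shown here alone, is whether phenyl or cyclohexyl on a saturated chain carbon bound to an amide-type nitrogen gives the stronger inhibitor, and where compound 2 and compound 3 stand relative to compound 1 at 501 nM.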